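The source may report more compounds than this note shows. Statements on the series, on what has been measured and on what is new or still open speak of the compounds shown alone.

Measured compounds in an ADME assay on HCT-116 cells (Homo sapiens) for cytotoxicity, read by MTT assay, with a stated time of 72 h; on this read-out higher numbers stand for weaker inhibition and lower numbers for stronger inhibition:
Compound 1 `COc1ccc(NC(=O)c2cccc(/C=C3\CC(=O)N(c4ccccc4)C3=O)c2)cc1` gives > 100000 nM, a limit of the assay.
Compound 2 `CCCCCN1C(=O)C/C(=C\c2cccc(C(=O)Nc3cccc(F)c3)c2)C1=O` gives > 100000 nM, also a limit.
Compound 3 `COc1ccc(NC(=O)c2cccc(/C=C3\CC(=O)N(c4ccc(C)cc4)C3=O)c2)cc1` gives > 100000 nM, again a limit.

Compound 1 thus stands only at a limit in this assay, as do the two others; no number separates them. Within the data shown here, the single one-place step, a step that the two limits leave unreadable from compound 1 to compound 3, is likewise unreadable between two limits. Compound 4 `Cc1ccc(NC(=O)c2cccc(/C=C3\CC(=O)N(c4ccccc4)C3=O)c2)cc1C` differs from compound 1 by 3,4-dimethylphenyl in place of 4-methoxyphenyl on an amide-type nitrogen. Among the measured compounds shown here, no measured step reads on this change; all that is known is that every value shown sits at the limit of > 100000 nM in this assay, at which 3 of the 3 values shown sit. No step beyond the scatter is therefore expected in this assay in either direction, and a limit rather than a number is the likely outcome. Compound 4 is estimated at 150000 nM, range 50000 nM to 500000 nM, meaning an expected step that the limit leaves unreadable from compound 1 to compound 4.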

Compound 4, half-maximal inhibitory concentration: > 100000 nM
Compound 4: no number, only a limit (the forecaster's own chance of this, stated with the estimate: 85%); the middle value does not contradict the limit.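

Among these compounds, compound 4 gives > 100000 nM, a limit, so no new step from compound 1 to compound 4 can be read. The compounds shown leave open whether any change on the shared core gives a number rather than a limit.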